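Halogen to tert-butyl swap on the benzyl ring

This account rests on a few compounds, and the source may have more. Where it says the series, first, only, none or still open, it means among the compounds named here.

Compound 3 `O=c1ccoc2cc(OCc3cn(Cc4ccc(Br)cc4)nn3)ccc12` in a functional assay on SW480 cells (Homo sapiens) for cytotoxicity, read by MTT assay, with a stated time of 48 h (a higher number here means a weaker inhibitor, a lower number a stronger inhibitor), gives 37500 nM, the highest of the two numbers in hand; the nearest is compound 2 `O=c1ccoc2cc(OCc3cn(Cc4ccc(F)cc4)nn3)ccc12`, which gives 11200 nM, and the step of a 3.3-fold higher number from compound 2 to compound 3 (0.52 log units; beyond the scatter) lies beyond the scatter. Compound 1 `O=c1ccoc2cc(OCc3cn(Cc4ccc(Cl)cc4)nn3)ccc12` reaches only > 100000 nM, a limit of the assay rather than a number (the limit of > 100000 nM in this assay, at which 1 of the 3 values shown sits). From compound 1 the steps of an at least 8.9-fold lower number from compound 1 to compound 2 (0.95 log units; beyond the scatter) and an at least 2.6-fold lower number from compound 1 to compound 3 (0.42 log units; beyond the scatter) were recorded, so compound 1 is the weakest of the three.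

Compound 4 `CC(C)(C)c1ccc(Cn2cc(COc3ccc4c(=O)ccoc4c3)nn2)cc1` differs from compound 3 by tert-butyl in place of bromo on an aromatic carbon. Within the data shown here, none of the measured steps involves a tert-butyl; all three exchange one halogen for another on the same aromatic carbon, and their sizes ran from modest to at least modest. With fluoro giving the lowest number and chloro only a limit, the step of a 1.6-fold higher number from compound 3 to compound 4 (0.20 log units; within the scatter) is expected to run toward a higher number, of modest size, with a fair chance that compound 4 also ends at a limit. For compound 4 the value in this assay is expected near 60000 nM, within 15000 nM to 200000 nM.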

Compound 4, half-maximal inhibitory concentration: 28800 nM
Compound 4: the middle estimate sits 2.1-fold (0.32 log units) above what was measured; the measured number falls inside the stated range.
By their numbers in this assay, from the lowest: compound 2; then compounds 4 and 3 (each within the scatter of the next). At a limit, above all of these: compound 1.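

In this assay, among these compounds, tert-butyl is the first non-halogen group at this position, on an aromatic carbon para to a large group, and it stays level with bromo: a 1.3-fold lower number from compound 3 to compound 4 (0.11 log units; within the scatter). Fluoro remains apart from tert-butyl, a 2.6-fold higher number from compound 2 to compound 4 (0.41 log units; beyond the scatter), so this position accepts four carbon heavy atoms with a number that stays within the scatter of the bromo compound, while the single-atom fluoro gives a distinct number. The chloro compound goes against any ordering by heavy-atom count, an at least 3.4-fold lower number from compound 1 to compound 4 (0.54 log units; beyond the scatter), but compound 1 stands at a limit, so that step is only a bound: the limit of > 100000 nM in this assay, at which 1 of the 4 values shown sits.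

As far as these compounds go, whether an amine or a carboxylic acid at this position would shift the number remains open. So does whether a longer alkyl chain would behave like tert-butyl.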